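Removing one methyl from compound 2

The source may hold more compounds than are shown below. What is called first, only, known or untested is meant among the compounds shown, and "the series" means these compounds.

In a functional assay on LOX IMVI cells (Homo sapiens) for cytotoxicity, read by MTT assay, with a stated time of 24 h (a lower number here means a stronger inhibitor, a higher number a weaker inhibitor), compound 1 (`COc1cc(-c2nc(-c3ccccc3)[nH]c2-c2ccnc(NCCCNS(=O)(=O)c3ccc(F)cc3)n2)ccc1Cl`) gives 4530 nM and compound 2 (`COc1cc(-c2nc(-c3ccccc3)[nH]c2-c2ccnc(NCCCNS(=O)(=O)c3cccc(F)c3)n2)ccc1Cl`) gives 5110 nM as its value. Among the measured compounds shown here, these two numbers cannot be told apart: the only measured step, a 1.1-fold higher number from compound 1 to compound 2 (0.05 log units; within the scatter), lies within the scatter and swaps 4-fluorophenyl for 3-fluorophenyl on a sulfonyl sulfur. Compound 2 therefore stands level with compound 1.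

Compound 3 (`O=S(=O)(NCCCNc1nccc(-c2[nH]c(-c3ccccc3)nc2-c2ccc(Cl)c(O)c2)n1)c1cccc(F)c1`) differs from compound 2 elsewhere in the molecule: hydrogen in place of methyl on an oxygen on an aromatic ring. This places hydrogen in place of methyl on an oxygen on an aromatic ring, so 4-chloro-3-methoxyphenyl becomes 4-chloro-3-hydroxyphenyl. For the measured compounds named here, the fluorine step from compound 1 to compound 2 does not touch this group, and no measured pair tests the change directly. The starting point for an expectation is thus compound 2 at 5110 nM in this assay, with no firm direction and no shift beyond the scatter expected. The expected change is a 1.3-fold lower number from compound 2 to compound 3 (0.11 log units; within the scatter) on this estimate. For compound 3 the estimated value is 4000 nM, with an expected range from 1500 nM to 10000 nM and wide margins on either side.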

Compound 3, half-maximal inhibitory concentration: 33600 nM
Estimate against measurement, compound 3: 8.4-fold (0.92 log units) below; measured number above the stated range.
By their numbers in this assay, from the lowest: compounds 1 and 2 (each within the scatter of the next); then compound 3.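

In this assay, taking the methyl off the oxygen on the aromatic ring, which turns methoxy into hydroxy, gives a 6.6-fold higher number from compound 2 to compound 3 (0.82 log units; beyond the scatter), so a change of just one heavy atom at this position weakens the compound by a clear margin. Among the compounds shown here, the earlier step, a 1.1-fold higher number from compound 1 to compound 2 (0.05 log units; within the scatter), moved a fluorine on the other side of the molecule and stayed within the scatter, so this is the first change that separates two compounds, and it shows that the 4-chloro-3-methoxyphenyl group is not indifferent to small edits. No measurement available here explains why the number rises at this position.

For the compounds shown here, the single pair cannot show whether the methyl itself matters or whether the free hydroxy is what costs activity, and an ethoxy group, with a longer chain on the same oxygen, or an amine in place of the oxygen would help tell these apart. On these data alone, it also remains open whether the same step would have the same size with the fluorine of compound 1 in place of that of compound 2.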